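A few compounds are considered here, and "the series" means these few. Any claim that something is new, unique, unknown or untested is made for them only; others in the source may bear on it.

Among the compounds with values here, compound 3 `Cc1ccccc1N(C)C(=O)c1ccc(-c2ccc(O)cc2Cl)o1` gives 14 nM in an assay on T47D cells for inhibition of 17-beta-hydroxysteroid dehydrogenase type 1 (Homo sapiens), read by HPLC, with a stated time of 24 h (a lower number here means a stronger inhibitor, a higher number a weaker inhibitor), the lowest of the three numbers measured so far. Compound 1 `Cc1ccccc1N(C)C(=O)c1ccc(-c2cccc(O)c2)o1` gives 29 nM in this assay, and compound 2 `Cc1ccccc1N(C)C(=O)c1ccc(-c2ccc(O)c(Cl)c2)o1` gives 52 nM in this assay. The step of a 2.1-fold lower number from compound 1 to compound 3 (0.32 log units; beyond the scatter) and the step of a 3.7-fold lower number from compound 2 to compound 3 (0.57 log units; beyond the scatter) both lie beyond the scatter, so compound 3 stands clearly apart from its two neighbours on the shared core.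

Compound 4 `Cc1ccccc1N(C)C(=O)c1ccc(-c2ccc(O)cc2F)o1` differs from compound 3 in one place: fluoro in place of chloro on an aromatic carbon. The 2-chloro-4-hydroxyphenyl of compound 3 thus becomes a 2-fluoro-4-hydroxyphenyl, with the hydroxy group left where it was.

Within the data shown here, none of the measured steps exchanges one halogen for another. The steps of a 2.1-fold lower number from compound 1 to compound 3 (0.32 log units; beyond the scatter) and a 3.7-fold lower number from compound 2 to compound 3 (0.57 log units; beyond the scatter) change where the hydroxy group and the chloro group sit, and the step of a 1.8-fold higher number from compound 1 to compound 2 (0.25 log units; within the scatter) adds a chloro at a different place and stays within the scatter. Among the measured compounds shown here, no measured step therefore bears directly on a chloro-to-fluoro swap at this position, and the expectation is a small step or none beyond the scatter, with the halogen kept at the same place.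

In this assay compound 4 is expected to give 22 nM, within a range from 8 nM to 60 nM. This estimate means a step of a 1.6-fold higher number from compound 3 to compound 4 (0.20 log units; within the scatter) that is expected to stay near the scatter.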

Compound 4, half-maximal inhibitory concentration: 10 nM
Compound 4: middle estimate off by 2.2-fold (0.34 log units), on the high side; the measured number falls inside the stated range.
By their numbers in this assay, from the lowest: compounds 4 and 3 (each within the scatter of the next); then compounds 1 and 2 (each within the scatter of the next).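

In this assay, the exchange of chloro for fluoro, on an aromatic carbon ortho to a large group and meta to a hydroxy group, is the only step among these compounds that swaps one halogen for another, and it stays within the scatter (a 1.4-fold lower number from compound 3 to compound 4 (0.15 log units; within the scatter)). The 2-fluoro-4-hydroxyphenyl also stands apart from the two other arrangements, beyond the scatter in both steps (a 2.9-fold lower number from compound 1 to compound 4 (0.46 log units; beyond the scatter); a 5.2-fold lower number from compound 2 to compound 4 (0.72 log units; beyond the scatter)), so the separation seen earlier with the 2-chloro-4-hydroxyphenyl is not confined to chloro among the two halogens shown. No measured evidence is available to explain why these two halogens give numbers within the scatter of each other.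

The compounds shown leave open whether bromo, methyl or plain hydrogen at the same place would give a number close to those of compound 3 and compound 4. They also leave open whether a methoxy group in place of the hydroxy group would keep the number in this range with either halogen present.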